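Alkyl in place of aryl on the chain carbon

The source may hold more compounds than are shown below. What is called first, only, known or untested is meant among the compounds shown, and "the series" means these compounds.

Measured so far in a functional assay (B cells) with Mus musculus as the target; a lower number here means that less compound is needed, a higher number that more compound is needed for the effect:
compound 1 `Nc1nc(O)c2c(n1)n(C1OC(CO)[C@@H](O)[C@H]1O)c(=O)n2CC(O)CSc1ccccc1`: 142 uM
compound 2 `N#Cc1cccc(Cn2c(=O)n(C3OC(CO)[C@@H](O)[C@H]3O)c3nc(N)nc(O)c32)c1`: 3 uM

In this assay, within the data shown here, compound 2 stands lowest of the two numbers; its only neighbour is compound 1, separated by a large step, a 47-fold lower number from compound 1 to compound 2 (1.68 log units; beyond the scatter). That is the whole of what is known about the substituent on the saturated chain carbon bound to an aromatic nitrogen.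

Compound 3 `CCn1c(=O)n(C2OC(CO)[C@@H](O)[C@H]2O)c2nc(N)nc(O)c21` has not been measured. It differs from compound 2 by methyl in place of 3-cyanophenyl on a saturated chain carbon bound to an aromatic nitrogen. Among the measured compounds shown here, the single step that bears on this position is a 47-fold lower number from compound 1 to compound 2 (1.68 log units; beyond the scatter); it shows that this substituent matters greatly, but both compounds in it carry a six-membered aromatic ring at some distance from the chain carbon, whereas compound 3 carries none. Nothing measured separates the 3-cyanophenyl from an empty position. Given the size of that step, a step toward a higher number, beyond the scatter, is expected for compound 3, a 17-fold higher number from compound 2 to compound 3 (1.22 log units; beyond the scatter). Compound 3 is therefore estimated at 50 uM, with a range from 10 uM to 250 uM.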

Compound 3, concentration for half-maximal effect: 15 uM
For compound 3 the middle estimate is 3.3-fold (0.52 log units) above the measured one; low and high end bracket the measured number.
By their numbers in this assay, from the lowest: compound 2; then compound 3; then compound 1.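

With no aromatic ring at all, the methyl of compound 3 keeps a number in the low range of this assay: the 3-cyanophenyl is not needed for an effect, and there is a 5.0-fold higher number from compound 2 to compound 3 (0.70 log units; beyond the scatter) as the price of its loss. The other side of the comparison is new as well, with a 9.5-fold lower number from compound 1 to compound 3 (0.98 log units; beyond the scatter), so the 1-hydroxy-2-(phenylsulfanyl)ethyl group stands worse than methyl here, and the large step between compound 1 and compound 2 splits into a part lost in compound 1 and a smaller part gained in compound 2. The two ring-bearing substituents thus fall on opposite sides of methyl, so among these compounds the presence of a six-membered aromatic ring does not by itself set the direction of the change. Nothing at hand accounts for these differences.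

From the compounds shown here alone, whether the gain in compound 2 belongs to the nitrile or to the phenyl ring stays open, and a plain benzyl group would bear directly on that. Equally open, going by these compounds, is how a longer alkyl chain, an amine or a carboxylic acid on the chain carbon would stand against methyl.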